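Swapping a benzyl sulfide for a tolyl sulfone

This account rests on a few compounds, and the source may have more. Where it says the series, first, only, none or still open, it means among the compounds named here.

Compound 1 (`COc1cc(OC)c(/C=C(\C(=O)c2ccc(Br)cc2)S(=O)(=O)c2ccc(C)cc2)c(OC)c1`): > 100000 nM (a limit)
Compound 2 (`COc1cc(OC)c(/C=C(/SCc2ccc(Cl)cc2Cl)C(=O)c2ccc(Cl)cc2)c(OC)c1`): 1000 nM (a number)

Within the data shown here, in a functional assay on DU-145 cells (Homo sapiens) for inhibition, read by trypan blue exclusion, with a stated time of 96 h (a higher number here means a weaker inhibitor of growth, a lower number a stronger inhibitor of growth), compound 2 gives 1000 nM and this is the only true number so far. Compound 3 (`COc1cc(OC)c(/C=C(\C(=O)c2ccc(Cl)cc2)S(=O)(=O)c2ccc(C)cc2)c(OC)c1`) carries (4-methylphenyl)sulfonyl in place of (2,4-dichlorobenzyl)sulfanyl on a double-bonded chain carbon bound to a carbonyl carbon and a double-bonded chain carbon. Compound 1 also carries (4-methylphenyl)sulfonyl and stands at > 100000 nM as a limit of the assay. A large step toward weaker growth inhibition is therefore expected, estimated as a 100-fold higher number from compound 2 to compound 3 (2.00 log units; beyond the scatter) in all. Compound 3 is estimated at 100000 nM (expected range 20000 nM to 200000 nM).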

Compound 3, concentration for 50% growth inhibition: 25000 nM
For compound 3 the middle estimate is 4.0-fold (0.60 log units) above the measured one; the range from low to high includes it.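

On this double-bonded chain carbon, (4-methylphenyl)sulfonyl in place of (2,4-dichlorobenzyl)sulfanyl weakens growth inhibition in this assay (a 25-fold higher number from compound 2 to compound 3 (1.40 log units; beyond the scatter)), yet compound 3 still gives a true number rather than a limit. With the sulfonyl group kept, chloro in place of bromo on an aromatic carbon also matters (an at least 4.0-fold lower number from compound 1 to compound 3 (0.60 log units; beyond the scatter)). That step is only a minimum, and its full size cannot be read: the limit of > 100000 nM in this assay, at which 1 of the 3 values shown sits.

Open, going by these compounds, is how a (2,4-dichlorobenzyl)sulfonyl group would compare, which would separate the change at sulfur from the change of aromatic group. On these data alone, how an amine at this place would compare also stays open.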